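The compounds below may be only part of what the source reports. "The series", "measured", "known", "first", "only" and "open" are said of these compounds alone.

Three compounds have been measured in a toxicity assay on cells (Macrophage, Mus musculus, strain BALB/c) for cytotoxicity, read by MTT assay; on this read-out lower numbers stand for stronger inhibition and higher numbers for weaker inhibition:

Compound 1 `COCc1cc(O)c(C(=O)/C=C/c2cc(OC)c(OC)c(OC)c2)c(OC)c1`: 133000 nM
Compound 2 `COc1cc(O)cc(O)c1C(=O)/C=C/c1ccc(Cl)cc1`: 19000 nM
Compound 3 `COc1cc(O)cc(O)c1C(=O)/C=C/c1ccccc1Br`: 14600 nM

Compound 2 lies within the scatter of compound 3 and far lower than compound 1 in this assay. Compound 4 `COc1cc(O)cc(O)c1C(=O)/C=C/c1ccc(C(F)(F)F)cc1` has not yet been measured and differs from compound 2 by trifluoromethyl in place of chloro on an aromatic carbon. Within the data shown here, the only measured step that bears on this change is a 1.3-fold lower number from compound 2 to compound 3 (0.11 log units; within the scatter), with 2-bromophenyl in place of 4-chlorophenyl. Among the measured compounds shown here, that step stays within the scatter, although no measured compound carries trifluoromethyl. The expected change is therefore a 1.1-fold lower number from compound 2 to compound 4 (0.05 log units; within the scatter), with no step beyond the scatter in either direction. Compound 4 is estimated at 17000 nM, with an expected range from 7500 nM to 38000 nM.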

Compound 4, half-maximal inhibitory concentration: 17100 nM
Compound 4: the middle estimate sits 1.0-fold (0.00 log units) below what was measured; the measured number falls inside the stated range.
By their numbers in this assay, from the lowest: compounds 3, 4 and 2 (each within the scatter of the next); then compound 1.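

In this assay, the swap on the aromatic carbon para to a large group gives a 1.1-fold lower number from compound 2 to compound 4 (0.05 log units; within the scatter) and stays within the scatter. Trifluoromethyl, with 4 heavy atoms, thus replaces chloro, with 1 heavy atom, at this position without a step beyond the scatter, which no earlier compound could show. Nothing measured here explains this result. The compounds shown leave open whether an amine or a carboxylic acid at this position would also stay within the scatter of compound 2. They also leave open whether trifluoromethyl would behave alike on the core of compound 1.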